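The source may hold more compounds than are shown below. What is called first, only, known or untested is meant among the compounds shown, and "the series" means these compounds.

Measured so far in a functional assay on OVCAR-8 cells (Homo sapiens) for cytotoxicity, read by sulforhodamine B assay, with a stated time of 48 h, tested at 10 uM; on this read-out lower numbers stand for a stronger effect and higher numbers for a weaker effect at the one concentration tested: compound 1 `COc1cc(-c2cc(/C=C/C(=O)c3ccc(N)cc3)[nH]n2)cc(OC)c1OC` gives -1%; compound 2 `COc1ccc(-c2cc(/C=C/C(=O)c3ccc(OC)c(OC)c3)[nH]n2)cc1` gives 1%; compound 3 `COc1cc(-c2cc(/C=C/C(=O)c3ccc(Cl)c(Cl)c3)[nH]n2)cc(OC)c1OC` gives 40%.

Compound 1 has the lowest of these three numbers. Within the data shown here, compound 2 lies within the scatter of it, while the one measured step, a number 41 percentage points higher from compound 1 to compound 3 (beyond the scatter), is large. Compound 4 `COc1ccc(-c2cc(/C=C/C(=O)c3ccc(N)cc3)[nH]n2)cc1OC` differs from compound 1 by hydrogen in place of methoxy on an aromatic carbon. That measured step changed the group on the carbonyl carbon, not the ring altered here, so it does not bear on this change. Compound 2, with fewer methoxy groups on that ring but also a different group on the carbonyl carbon, gives a value close to compound 1. No step beyond the scatter is expected in this assay, the estimated step being a number 4 percentage points higher from compound 1 to compound 4 (within the scatter). Compound 4 is therefore estimated at 3%, between -15% and 25%.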

Compound 4, a percentage reported as activity, at one concentration (the size of the read-out at that concentration, not a potency): 2%
For compound 4 the middle estimate is 1 percentage points above the measured one, and the stated range covers the measured number.
By their numbers in this assay, from the lowest: compounds 1, 2 and 4 (each within the scatter of the next); then compound 3.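

In this assay, hydrogen in place of this methoxy group gives a number 3 percentage points higher from compound 1 to compound 4 (within the scatter). With the 4-aminophenyl group on the carbonyl carbon, this one methoxy group can therefore be lost without a step beyond the scatter. Among these compounds, this is the only single-place step on this ring, since the earlier one changed the group on the carbonyl carbon.

Still open, as far as these compounds go, is how a hydroxyl or an ethoxy group would read at this place, and whether the same swap would hold with 3,4-dichlorophenyl on the carbonyl carbon. Nothing measured here explains the result.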